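This account rests on a few compounds, and the source may have more. Where it says the series, first, only, none or still open, it means among the compounds named here.

Measured so far:
compound 1, `COc1ccccc1Oc1c(N)nc(-c2ccccc2F)nc1Cl`, 13800 nM;
compound 2, `COc1ccccc1Oc1c(N)nc(-c2cccc(F)c2)nc1Cl`, 21700 nM;
compound 3, `COc1ccccc1Oc1c(N)nc(-c2ccccc2F)nc1OCCO`, 11800 nM.

These three compounds were tested in a functional assay on B16 cells (Mus musculus) for cytotoxicity, read by CCK-8 assay, with a stated time of 24 h (on this read-out lower numbers stand for stronger inhibition and higher numbers for weaker inhibition), and the numbers above are what each gave. Compound 3 is set apart from compound 1 by 2-hydroxyethoxy in place of chloro on an aromatic carbon; the change it brings is a 1.2-fold lower number from compound 1 to compound 3 (0.07 log units; within the scatter). Compound 2 is set apart from compound 1 by 3-fluorophenyl in place of 2-fluorophenyl on an aromatic carbon; the step it brings is a 1.6-fold higher number from compound 1 to compound 2 (0.20 log units; within the scatter). Both steps are within the usual scatter of repeated measurements, so the three numbers are not told apart by the data.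

Compound 4, `COc1ccccc1Oc1c(N)nc(-c2cccc(F)c2)nc1OCCO`, has not been measured in this assay. It is set apart from compound 3 by 3-fluorophenyl in place of 2-fluorophenyl on an aromatic carbon. This is the same kind of change as that from compound 1 to compound 2, but the surroundings are not the same: in compound 3 the place is meta to a 2-hydroxyethoxy group and para to a 2-methoxyphenoxy group, where in compound 1 it is meta to a chloro group and para to a group of 9 heavy atoms.

For the measured compounds named here, for compound 4 the expected step is a 1.6-fold higher number from compound 3 to compound 4 (0.20 log units; within the scatter), because the only earlier instance of this kind of change gave a 1.6-fold higher number from compound 1 to compound 2 (0.20 log units; within the scatter). The estimate for compound 4 in this assay is 18500 nM. The expected range for compound 4 runs from 9000 nM to 40000 nM.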

Compound 4, half-maximal inhibitory concentration: 20900 nM
Compound 4: the middle estimate sits 1.1-fold (0.05 log units) below what was measured, and the stated range covers the measured number.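

In this assay, 3-fluorophenyl in place of 2-fluorophenyl on the core bearing the 2-hydroxyethoxy group gives a 1.8-fold higher number from compound 3 to compound 4 (0.25 log units; within the scatter), and this step agrees with the one seen on the core bearing chloro: the same change on two cores in this assay, a 1.6-fold higher number (0.20 log units; within the scatter) from compound 1 to compound 2 and a 1.8-fold higher number (0.25 log units; within the scatter) from compound 3 to compound 4, 1.1-fold (0.05 log units) apart, within the scatter of two such steps. The other change, 2-hydroxyethoxy in place of chloro, gives a 1.0-fold lower number from compound 2 to compound 4 (0.02 log units; within the scatter) on the core carrying 3-fluorophenyl, and it too agrees with its earlier instance: the same change on two cores in this assay, a 1.2-fold lower number (0.07 log units; within the scatter) from compound 1 to compound 3 and a 1.0-fold lower number (0.02 log units; within the scatter) from compound 2 to compound 4, 1.1-fold (0.05 log units) apart, within the scatter of two such steps. Within these four compounds, each change therefore looks the same on both cores, but since every step lies within the scatter, this shows only that neither change produced a measurable shift on either core, not that a real effect of either change carries from one core to another.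

The compounds shown leave open whether an amine, a carboxylic acid or a longer chain in place of the 2-hydroxyethoxy group would give a step beyond the scatter in this assay. As far as these compounds go, it also remains open whether an unsubstituted phenyl in place of the fluorophenyl group, or a phenoxy group without the methoxy in place of the 2-methoxyphenoxy group, would separate these numbers.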